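A Methoxy for Chloro Swap on a Triazole Side Chain

The source may report more compounds than this note shows. Statements on the series, on what has been measured and on what is new or still open speak of the compounds shown alone.

Measured in a functional assay on SMMC-7721 cells (Homo sapiens) for cytotoxicity, read by MTT assay, with a stated time of 4 days; on this read-out lower numbers stand for stronger inhibition and higher numbers for weaker inhibition:
compound 1 `C=C1C[C@]23C[C@@]1(O)CC[C@H]2c1ccc(OS(=O)(=O)c2ccc(C)cc2)c(C)c1[C@@H]3Cn1cc(-c2ccc(Cl)cc2)nn1` gives > 20000 nM
compound 2 `Cc1c(O)ccc2c1[C@H](Cn1cc(-c3ccc(F)cc3)nn1)[C@@]13CC(=O)[C@@](C)(CC[C@@H]21)C3` gives > 20000 nM

Compound 1 stands at the limit of > 20000 nM in this assay, at which 2 of the 2 values shown sit; its value is a limit of the assay and not a number. Compound 2 likewise sits at a limit, so no numerical ranking between the two measured compounds can be drawn. Compound 3 `C=C1C[C@]23C[C@@]1(O)CC[C@H]2c1ccc(OS(=O)(=O)c2ccc(C)cc2)c(C)c1[C@@H]3Cn1cc(-c2ccc(OC)cc2)nn1` has not yet been measured; it differs from compound 1 by methoxy in place of chloro on an aromatic carbon. Among the compounds with values here, no step between measured compounds is available to set a size for such a change, so the expectation rests on the limit alone. The step that the limit leaves unreadable from compound 1 to compound 3 is expected to stay within the scatter, with no direction beyond it. For compound 3 the estimate in this assay is 30000 nM, with a range from 10000 nM to 100000 nM, and most likely only a limit will be reported.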

Compound 3, half-maximal inhibitory concentration: > 20000 nM
Compound 3: no number, only a limit; the forecaster's own chance of this, stated with the estimate: 75%; the middle value does not contradict the limit.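

In this assay compound 3 gives > 20000 nM, a limit and not a number. No step from compound 1 to compound 3 can be read, because both sit at the same limit: the limit of > 20000 nM in this assay, at which 3 of the 3 values shown sit.

The compounds shown leave open whether methoxy in place of chloro changes cytotoxicity at all.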